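Working notes: 4-bromobenzyl to allyl on the sulfur

This account rests on a few compounds, and the source may have more. Where it says the series, first, only, none or still open, it means among the compounds named here.

Values in a functional assay on MGC-803 cells (Homo sapiens) for inhibition, read by MTT assay, with a stated time of 72 h (a lower number here means a stronger inhibitor, a higher number a weaker inhibitor), are these:
- compound 1 (`Cc1cc(Nc2cc(-c3cccs3)[nH]n2)n2nc(SCc3ccc(Br)cc3)nc2n1`) gives 3770 nM
- compound 2 (`Cc1cc(Nc2ccn(Cc3ccccc3)n2)n2nc(SCc3ccc(Br)cc3)nc2n1`) gives 4720 nM
- compound 3 (`Cc1cc(Nc2cc(-c3ccccc3)[nH]n2)n2nc(SCc3ccc(Br)cc3)nc2n1`) gives 1110 nM

Compound 3 holds the lowest of the three numbers, and its gaps to compound 1 and compound 2 both lie beyond the scatter. Compound 4 (`C=CCSc1nc2nc(C)cc(Nc3cc(-c4ccccc4)[nH]n3)n2n1`), not yet measured, has vinyl in place of 4-bromophenyl on a saturated chain carbon bound to a sulfur. For the measured compounds named here, the only measured step is a 3.4-fold lower number from compound 1 to compound 3 (0.53 log units; beyond the scatter) and it concerns phenyl in place of thiophen-2-yl on an aromatic carbon. All three measured compounds carry the same (4-bromobenzyl)sulfanyl group, so that step guides size only and does not test this change. A step of similar or slightly larger size is expected in this assay toward a higher number. Going by the values given here, this direction is a weak expectation, resting on compound 3 at 1110 nM being the lowest number so far. The expected step is a 3.2-fold higher number from compound 3 to compound 4 (0.50 log units; beyond the scatter) and remains an estimate. Compound 4 is expected at 3500 nM (estimated range 1100 nM to 12000 nM).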

Compound 4, half-maximal inhibitory concentration: 17200 nM
Compound 4: middle estimate off by 4.9-fold (0.69 log units), on the low side; measured number outside the range, above it.
By their numbers in this assay, from the lowest: compound 3; then compounds 1 and 2 (each within the scatter of the next); then compound 4.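

In this assay, for the compounds shown here, the change from (4-bromobenzyl)sulfanyl to allylsulfanyl gives a 15-fold higher number from compound 3 to compound 4 (1.19 log units; beyond the scatter), a larger step than the one earlier change, a 3.4-fold lower number from compound 1 to compound 3 (0.53 log units; beyond the scatter). The group on the sulfur therefore has a strong bearing on the number in this series, at least for this pair, in which the rest of the molecule stays the same. The aromatic ring and the bromine leave together in this change, so this pair cannot assign the step to either one, and no measurement at hand accounts for its size.

A plain benzyl or a 4-chlorobenzyl on the sulfur would separate the part played by the bromine from that of the ring, while a longer alkyl chain would test whether size alone tracks the number. As far as these compounds go, whether the step carries over to compound 1, with its thiophen-2-yl group, also remains open.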